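Naphthyl Urea in a Bicyclic Pyrimidine Series of Ret Inhibitors

The compounds below may be only part of what the source reports. "The series", "measured", "known", "first", "only" and "open" are said of these compounds alone.

Measured compounds:
compound 1 `O=C(Nc1ccc(Nc2ncnc3c2OCCN3)cc1)Nc1ccc(Cl)c(C(F)(F)F)c1`: 177 nM
compound 2 `COc1ccc(NC(=O)Nc2ccc(Nc3ncnc4c3OCCN4)cc2)cc1`: 227 nM
compound 3 `Cc1ccc(F)c(NC(=O)Nc2ccc(Nc3ncnc4c3OCCN4)cc2)c1`: 1470 nM

These three compounds share one core and differ only in the aryl group on the distal urea nitrogen. In an assay on isolated protein for inhibition of proto-oncogene tyrosine-protein kinase receptor Ret (Homo sapiens), read by 33P incorporation, with stated times of 15 min and 40 min (a higher number here means a weaker inhibitor, a lower number a stronger inhibitor), compound 3 gives 1470 nM, the highest number of the three. Compound 2 sits nearest to it, and the step of a 6.5-fold higher number from compound 2 to compound 3 (0.81 log units; beyond the scatter) lies beyond the scatter. Compound 1 lies furthest away, its value also well separated from that of compound 3.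

Compound 4 `O=C(Nc1ccc(Nc2ncnc3c2OCCN3)cc1)Nc1cccc2ccccc12` has not yet been measured. It differs from compound 3 in one place: naphthalen-1-yl in place of 2-fluoro-5-methylphenyl on an amide-type nitrogen. Going by the values given here, the one step that bears on a change at this nitrogen is the one from compound 2 to compound 3, which shows that the aryl group here can move the number by a modest amount. Since compound 3 is the weakest of the three, and the other two aryl groups both gave lower numbers, compound 4 is expected to return part of the way: the expected step is a 3.3-fold lower number from compound 3 to compound 4 (0.51 log units; beyond the scatter). The estimate for compound 4 in this assay is 450 nM, with a range from 100 nM to 2000 nM.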

Compound 4, half-maximal inhibitory concentration: > 10000 nM
Compound 4 gave a limit, no number; the forecaster's own chance of this, stated with the estimate: 3%; middle value at least 22-fold (1.34 log units) away from the limit.
By their numbers in this assay, from the lowest: compounds 1 and 2 (each within the scatter of the next); then compound 3. At a limit, above all of these: compound 4.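

Compound 4 gives only a limit in this assay, not a number: the limit of > 10000 nM in this assay, at which 1 of the 4 values shown sits. Read against that limit, the change to naphthalen-1-yl is an at least 6.8-fold higher number from compound 3 to compound 4 (0.83 log units; beyond the scatter) and, against the 4-methoxyphenyl compound, an at least 44-fold higher number from compound 2 to compound 4 (1.64 log units; beyond the scatter) and so this amide-type nitrogen tolerates less variation than the earlier modest step suggested. Among the four compounds, naphthalen-1-yl is the only group with two six-membered aromatic rings and the only one that reaches the limit, though a single compound cannot establish a pattern.

The compounds shown cannot tell whether the loss goes with the second ring itself or with the way that ring is attached. Naphthalen-2-yl or an unsubstituted phenyl on this nitrogen would be needed to separate those two readings.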